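Benzoyl to Propylcarbonyl in a Growth Inhibitor

The source may report more compounds than this note shows. Statements on the series, on what has been measured and on what is new or still open speak of the compounds shown alone.

In a functional assay on HCT-116 cells (Homo sapiens), read by crystal violet staining, with a stated time of 6 days (a lower number here means a stronger inhibitor of growth, a higher number a weaker inhibitor of growth), compound 1 (`COc1ccc([C@@H]2CC(=O)c3c(O)cc(OC(=O)c4ccccc4)cc3O2)cc1O`) gives 16500 nM and compound 2 (`COc1ccc(C(=O)Oc2cc(O)c3c(c2)O[C@H](c2ccc(OC)c(OC(=O)c4ccc(OC)cc4)c2)CC3=O)cc1`) gives 35700 nM. Compound 1 therefore holds the lower of the two numbers, and the gap lies beyond the usual scatter. Compound 3 (`CCCC(=O)Oc1cc(O)c2c(c1)O[C@H](c1ccc(OC)c(O)c1)CC2=O`) has propyl in place of phenyl on a carbonyl carbon, which turns benzoyloxy into (propylcarbonyl)oxy. Among the compounds with values here, no measured pair shows this kind of change, so the evidence is thin, and the expected step of a 1.2-fold higher number from compound 1 to compound 3 (0.08 log units; within the scatter) stays within the scatter in either direction. Compound 3 is estimated at 20000 nM (expected range 7000 nM to 50000 nM) in this assay once tested.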

Compound 3, concentration for 50% growth inhibition: 12000 nM
The estimate for compound 3 lay 1.7-fold (0.22 log units) above the measured number; the measured number falls inside the stated range.
By their numbers in this assay, from the lowest: compounds 3 and 1 (each within the scatter of the next); then compound 2.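

With phenyl or propyl on this carbonyl carbon, growth inhibition in this assay stays within the scatter, with a 1.4-fold lower number from compound 1 to compound 3 (0.14 log units; within the scatter) as the step. At this position, then, the six-membered aromatic ring is not required to hold this level of activity, and the smaller propyl group serves as well. No available measurement explains this result. Still open, on these data alone, is whether a longer chain such as hexyl, a branched chain such as isopropyl, or a chain carrying an amine would do better or worse here.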